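A few compounds are considered here, and "the series" means these few. Any claim that something is new, unique, unknown or untested is made for them only; others in the source may bear on it.

Measured so far:
compound 1 `COc1ccccc1C(=O)Nc1nnc(SCC(=O)Nc2ccc(Br)cn2)s1`, in a functional assay on HeLa cells (Homo sapiens) for antiproliferative activity, read by MTT assay, with a stated time of 48 h (on this read-out lower numbers stand for stronger inhibition and higher numbers for weaker inhibition), only a limit: > 80000 nM.
compound 2 `O=C(CSc1nnc(NC(=O)CCl)s1)Nc1ccc(Br)cn1`, in this assay: 3400 nM.

For the measured compounds named here, compound 2 holds the only number in this assay; the other entry is a limit. The unmeasured compound 3 `O=C(CSc1nnc(NC(=O)CCCl)s1)Nc1ccc(Br)cn1` differs from compound 2 by chloromethyl in place of chloro on a saturated chain carbon bound to a carbonyl carbon. Going by the values given here, one measured step bears on it: an at least 23-fold lower number from compound 1 to compound 2 (1.37 log units; beyond the scatter), which exchanged the whole group on the carbonyl carbon and was large. Compound 1 sits at the limit of > 80000 nM in this assay, at which 1 of the 2 values shown sits. The step to compound 3 is a smaller change within that same group, so the expected step of a 3.5-fold higher number from compound 2 to compound 3 (0.55 log units; beyond the scatter) is toward a higher number, probably beyond the scatter but uncertain. Compound 3 is estimated at 12000 nM, range 3000 nM to 50000 nM.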

Compound 3, half-maximal inhibitory concentration: 5300 nM
The estimate for compound 3 lay 2.3-fold (0.35 log units) above the measured number; the range from low to high includes it.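

The change from chloromethyl to 2-chloroethyl gives a 1.6-fold higher number from compound 2 to compound 3 (0.19 log units; within the scatter), so these two groups on the carbonyl carbon cannot be told apart here. The large gap to the 2-methoxyphenyl amide recurs with the second chain, an at least 15-fold lower number from compound 1 to compound 3 (1.17 log units; beyond the scatter), so it is not confined to chloromethyl. That step remains open-ended, as the value of compound 1 is a limit: the limit of > 80000 nM in this assay, at which 1 of the 3 values shown sits.

The compounds shown leave open whether the chlorine matters, as against a plain ethyl on the same carbonyl carbon. As far as these compounds go, how a longer chlorine-bearing chain would read also stays open.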